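A few compounds are considered here, and "the series" means these few. Any claim that something is new, unique, unknown or untested is made for them only; others in the source may bear on it.

Working notes on the series. Compound 1 `COc1cc(NC(C)CCCNC(=O)NNC(=O)N(CCO)CCO)c2ncccc2c1` carries the bis(2-hydroxyethyl)amino terminus; in a functional assay on MIA PaCa-2 cells (Homo sapiens) for inhibition, read by MTT assay, with a stated time of 4 days (on this read-out lower numbers stand for stronger inhibition and higher numbers for weaker inhibition), compound 1 returns only a limit, > 250000 nM, so its position here rests on the limit of > 250000 nM in this assay, at which 1 of the 3 values shown sits, rather than on a number. Two further members give numbers in this assay: compound 2 `COc1ccc(/C(=N/NC(=O)NCCCC(C)Nc2cc(OC)cc3cccnc23)c2ccccc2)cc1` gives 155000 nM, and compound 3 `O=C(NC(c1ccccc1)c1ccc(Cl)cc1)n1nnc2ccccc21` gives 110000 nM. Compound 4 `COc1cc(NC(C)CCCNC(=O)NNC(=O)NCCCO)c2ncccc2c1` differs from compound 1 at one site: (3-hydroxypropyl)amino in place of bis(2-hydroxyethyl)amino on a carbonyl carbon. For the measured compounds named here, with no measured pair of this kind to lean on, the step from compound 1 to compound 4 is expected to stay within the scatter, and compound 4 is expected to come back as a limit as well. The estimate for compound 4 in this assay is 300000 nM, within 150000 nM to 600000 nM. That estimate means an expected step that the limit leaves unreadable from compound 1 to compound 4.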

Compound 4, half-maximal inhibitory concentration: >= 250000 nM
Compound 4 was reported as a limit; the forecaster's own chance of this, stated with the estimate: 80%; the middle value does not contradict the limit.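

For the compounds shown here, compound 1 and compound 4 both return only limits in this assay, and no step between them can be read. The compounds shown leave open what (3-hydroxypropyl)amino in place of bis(2-hydroxyethyl)amino does to the read-out.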